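Removing one trifluoromethyl from the hydrazone aryl

The source may hold more compounds than are shown below. What is called first, only, known or untested is meant among the compounds shown, and "the series" means these compounds.

Compound 2 `CN(C(=O)NC(=O)c1cccc(C(F)(F)F)c1)c1nc(C(F)(F)F)c(C(=O)N/N=C/c2cc(C(F)(F)F)cc(C(F)(F)F)c2)s1` gives 5.34 ug/mL in a functional assay on HeLa cells (Homo sapiens) for inhibition, read by MTT assay, with a stated time of 72 h (a lower number here means a stronger inhibitor, a higher number a weaker inhibitor), and stands lowest of the two numbers measured. Compound 3 `CN(C(=O)NC(=O)c1ccc(C(F)(F)F)cc1)c1nc(C(F)(F)F)c(C(=O)N/N=C/c2cc(C(F)(F)F)cc(C(F)(F)F)c2)s1` gives 5.78 ug/mL in this assay, and the step of a 1.1-fold higher number from compound 2 to compound 3 (0.03 log units; within the scatter) lies within the scatter. Compound 1 `CN(C(=O)NC(=O)c1ccc(Cl)cc1Cl)c1nc(C(F)(F)F)c(C(=O)N/N=C/c2cc(C(F)(F)F)cc(C(F)(F)F)c2)s1` reaches only the assay limit, > 100 ug/mL in this assay, so that value is a limit and not a number (the limit of > 100 ug/mL in this assay, at which 1 of the 3 values shown sits). The steps of an at least 18-fold lower number from compound 1 to compound 2 (1.27 log units; beyond the scatter) and an at least 17-fold lower number from compound 1 to compound 3 (1.23 log units; beyond the scatter) are large, but both change the aryl on the carbonyl carbon, not the hydrazone side.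

Compound 4 `CN(C(=O)NC(=O)c1cccc(C(F)(F)F)c1)c1nc(C(F)(F)F)c(C(=O)N/N=C/c2cccc(C(F)(F)F)c2)s1` differs from compound 2 by hydrogen in place of trifluoromethyl on an aromatic carbon. Within the data shown here, no measured step touches this ring, so the measured steps give no direct bearing on the change; the expectation is therefore no step beyond the scatter in this assay, with wide uncertainty. The expected step is a 1.5-fold higher number from compound 2 to compound 4 (0.18 log units; within the scatter). Compound 4 is estimated at 8 ug/mL in this assay, within a range of 2 ug/mL to 40 ug/mL.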

Compound 4, half-maximal inhibitory concentration: 4.81 ug/mL
Compound 4: the middle estimate sits 1.7-fold (0.22 log units) above what was measured, within the range that was stated.
By their numbers in this assay, from the lowest: compounds 4, 2 and 3 (each within the scatter of the next). At a limit, above all of these: compound 1.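

On the hydrazone aryl, the step of a 1.1-fold lower number from compound 2 to compound 4 (0.05 log units; within the scatter) shows that in this assay this aromatic carbon accepts hydrogen in place of trifluoromethyl, so the second trifluoromethyl on that ring is not needed to keep the number at this level. Among these compounds, this is the first reading on the hydrazone side, since the earlier steps all changed the aryl on the carbonyl carbon. Nothing measured on these compounds bears on why the step stays so small.

From the compounds shown here alone, whether the remaining trifluoromethyl on that ring is needed stays open, as does the outcome with an amine, a carboxylic acid or a methoxy group at either place on it. Also open, going by these compounds, is whether the same replacement holds when 4-(trifluoromethyl)phenyl or 2,4-dichlorophenyl sits on the carbonyl carbon.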